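Methyl to Methoxy on the Core: Expected Receptor Binding

A few compounds are considered here, and "the series" means these few. Any claim that something is new, unique, unknown or untested is made for them only; others in the source may bear on it.

Of the compounds shown here, three have been measured in an assay on isolated protein for displacement of a labelled ligand from metabotropic glutamate receptor 5 (Homo sapiens), with a stated time of 60 min, tested at 1 uM; a lower number here means less inhibition, a higher number more inhibition at the concentration tested (going by the name of the read-out). Compound 1 `COc1ccc(S(=O)(=O)c2cnc3ccc(OC)cc3c2N2CCC(C)CC2)cc1` gives 41%. For the measured compounds named here, compound 2 `COc1ccc2ncc(S(=O)(=O)c3ccc(Cl)c(Cl)c3)c(N3CCC(C)CC3)c2c1` gives 87%, and the single measured step, a number 46 percentage points higher from compound 1 to compound 2 (beyond the scatter), is the only change whose effect is known here. Compound 3 `Cc1ccc2ncc(S(=O)(=O)c3cccc(C#N)c3)c(N3CCC(C)CC3)c2c1` gives 52%, which places it second highest of the three, above compound 1 and well below compound 2.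

Compound 4 `COc1ccc2ncc(S(=O)(=O)c3cccc(C#N)c3)c(N3CCC(C)CC3)c2c1` differs from compound 3 in one place: methoxy in place of methyl on an aromatic carbon. The change sits on an aromatic carbon of a six-membered aromatic ring of carbon only, part of a fused or bridged system of two rings, on the shared core. Going by the values given here, the step from compound 1 to compound 2 concerns the group on the sulfonyl sulfur, not the core, so no measured step bears directly on this change. With nothing to point either way, the expected step is no change at the digits printed from compound 3 to compound 4 (within the scatter). Compound 4 is therefore estimated at 52%, with a range from 32% to 72%.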

Compound 4, a percentage reported as inhibition, at one concentration (the size of the read-out at that concentration, not a potency): 90%
Estimate against measurement, compound 4: 38 percentage points below, outside the stated range (above it).
By their numbers in this assay, from the lowest: compound 1; then compound 3; then compounds 2 and 4 (each within the scatter of the next).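

In this assay, methoxy in place of methyl on an aromatic carbon of the shared core gives a number 38 percentage points higher from compound 3 to compound 4 (beyond the scatter), the first sign that this core position, and not only the group on the sulfonyl sulfur, can move the read-out. With methoxy on the core, 3-cyanophenyl in place of 3,4-dichlorophenyl on the sulfonyl sulfur gives a number 3 percentage points higher from compound 2 to compound 4 (within the scatter), while 3-cyanophenyl in place of 4-methoxyphenyl gives a number 49 percentage points higher from compound 1 to compound 4 (beyond the scatter), so the two sulfonyl groups in compound 2 and compound 4 cannot be told apart here. Nothing available explains why methoxy and methyl differ at this position.

As far as these compounds go, whether the step from methyl to methoxy would be as large with a sulfonyl group other than 3-cyanophenyl remains open. So does what an ethoxy group, a hydroxyl group or an amine would do at this position on the core.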